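Swapping Chloro for Methoxy on an Antiproliferative Series

The compounds below may be only part of what the source reports. "The series", "measured", "known", "first", "only" and "open" are said of these compounds alone.

In a functional assay on B16-F10 cells (Mus musculus) for antiproliferative activity, read by MTT assay, with a stated time of 48 h (a lower number here means a stronger inhibitor, a higher number a weaker inhibitor), compound 2 (`Clc1ccc(NCc2cn(-c3ccccc3)nc2-c2ccc(Cl)cc2)cc1`) gives 2450 nM and holds the lower of the two numbers, while compound 1 (`COc1ccc(-c2nn(-c3ccccc3)cc2CNc2ccc(C)cc2)cc1`) gives 8380 nM, a gap beyond the scatter. Compound 3 (`COc1ccc(-c2nn(-c3ccccc3)cc2CNc2ccc(Cl)cc2)cc1`) has methoxy in place of chloro on an aromatic carbon, turning 4-chlorophenyl into 4-methoxyphenyl (methoxy in place of chloro on an aromatic carbon). Among the compounds with values here, no measured step isolates this change. A weaker number is expected in this assay because compound 1 with its 4-methoxyphenyl gives 8380 nM here. The expected 2.0-fold higher number from compound 2 to compound 3 (0.31 log units; beyond the scatter) is a moderate rise. For compound 3 the estimate is 5000 nM, with an expected range from 2000 nM to 12000 nM in this measurement.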

Compound 3, half-maximal inhibitory concentration: 7180 nM
Estimate against measurement, compound 3: 1.4-fold (0.16 log units) below; measured number inside the range.
By their numbers in this assay, from the lowest: compound 2; then compounds 3 and 1 (each within the scatter of the next).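

In this assay, replacing 4-chlorophenyl with 4-methoxyphenyl is now isolated as a single change, and it gives a 2.9-fold higher number from compound 2 to compound 3 (0.47 log units; beyond the scatter) at this position, so the position does respond to this change. Chloro in place of methyl on an aromatic carbon gives a 1.2-fold lower number from compound 1 to compound 3 (0.07 log units; within the scatter) and does not separate these two compounds. Nothing measured here explains either step. As far as these compounds go, whether fluoro, an amine or a carboxylic acid in this place would match compound 2 remains open. So does whether the step from chloro to methoxy would hold on a different core.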